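Fluoro for methyl on the fused ring: compound 4

The source may hold more compounds than are shown below. What is called first, only, known or untested is meant among the compounds shown, and "the series" means these compounds.

Measured in an assay for inhibition of Polyunsaturated fatty acid 5-lipoxygenase (Homo sapiens), read by HPLC, with a stated time of 15 min; on this read-out lower numbers stand for stronger inhibition and higher numbers for weaker inhibition:
compound 1, `COc1cc(-c2nc3ccc(C)cn3c2NC2CCCCC2)ccc1OCCCNC(=O)Nc1ccc(C(F)(F)F)cc1`: 439 nM
compound 2, `COc1cc(-c2nc3ccc(F)cn3c2NC2CCCCC2)ccc1OCCCNC(=O)Nc1ccc(C(F)(F)F)cc1`: 649 nM
compound 3, `COc1cc(-c2nc3ccc(C)cn3c2NC2CCCC2)ccc1OCCCNC(=O)Nc1ccc(C(F)(F)F)cc1`: 614 nM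

In this assay the number for compound 3 lies between those of compound 1 and compound 2, and all three lie within the scatter of one another.

Compound 4, `COc1cc(-c2nc3ccc(F)cn3c2NC2CCCC2)ccc1OCCCNC(=O)Nc1ccc(C(F)(F)F)cc1`, differs from compound 3 by fluoro in place of methyl on an aromatic carbon. The same exchange was measured once on the cyclohexyl analogue, a 1.5-fold higher number from compound 1 to compound 2 (0.17 log units; within the scatter). The other measured step, a 1.4-fold higher number from compound 1 to compound 3 (0.15 log units; within the scatter), concerns the cyclopentyl and does not bear on this change. Carrying the single relevant step over, the expected step is a 1.5-fold higher number from compound 3 to compound 4 (0.17 log units; within the scatter), a higher number at the edge of the scatter. Compound 4 is therefore estimated at 900 nM, with a range of 450 nM to 1800 nM.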

Compound 4, half-maximal inhibitory concentration: 480 nM
Compound 4: the middle estimate sits 1.9-fold (0.27 log units) above what was measured; the measured number falls inside the stated range.
By their numbers in this assay, from the lowest: compounds 1, 4, 3 and 2 (each within the scatter of the next).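

With the cyclopentyl on the nitrogen, fluoro in place of methyl on the aromatic carbon gives a 1.3-fold lower number from compound 3 to compound 4 (0.11 log units; within the scatter), so no direction can be assigned to this exchange at this position: the same change on two cores in this assay, a 1.5-fold higher number (0.17 log units; within the scatter) from compound 1 to compound 2 and a 1.3-fold lower number (0.11 log units; within the scatter) from compound 3 to compound 4, 1.9-fold (0.28 log units) apart, within the scatter of two such steps. On the fluoro core, cyclopentyl in place of cyclohexyl gives a 1.4-fold lower number from compound 2 to compound 4 (0.13 log units; within the scatter), and no direction can be assigned to that exchange either: the same change on two cores in this assay, a 1.4-fold higher number (0.15 log units; within the scatter) from compound 1 to compound 3 and a 1.4-fold lower number (0.13 log units; within the scatter) from compound 2 to compound 4, 1.9-fold (0.28 log units) apart, within the scatter of two such steps. Neither exchange therefore separates these four compounds. Still open, on these data alone, is whether chloro, methoxy or a nitrile on this aromatic carbon, or cyclopropyl on the nitrogen, would give a step beyond the scatter.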